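A Single Fluorine Added to the Phenyl of Compound 2

The source may report more compounds than this note shows. Statements on the series, on what has been measured and on what is new or still open speak of the compounds shown alone.

Among the compounds with values here, compound 2 `CN(C)CCn1cnnc1-c1cc(Oc2ccc(NC(=O)N/N=C/c3ccccc3)cc2F)ccn1` stands as the lowest of the two numbers so far in a functional assay on HT-29 cells (Homo sapiens) for cytotoxicity, read by MTT assay, with a stated time of 72 h (on this read-out lower numbers stand for stronger inhibition and higher numbers for weaker inhibition), where compound 2 gives 1120 nM. Its nearest neighbour is compound 1 `COc1ccc(/C=N/NC(=O)Nc2ccc(Oc3ccnc(-c4nncn4CCN(C)C)c3)c(F)c2)c(OC)c1OC`, which in this assay gives 3970 nM. The step of a 3.5-fold lower number from compound 1 to compound 2 (0.55 log units; beyond the scatter) arose from phenyl replacing 2,3,4-trimethoxyphenyl on a carbon with a double bond to nitrogen. Compound 3 `CN(C)CCn1cnnc1-c1cc(Oc2ccc(NC(=O)N/N=C/c3ccc(F)cc3)cc2F)ccn1` differs from compound 2 by fluoro in place of hydrogen on an aromatic carbon of the six-membered aromatic ring of carbon only, para to a large group. Within the data shown here, the one measured step bears on this only loosely, since it exchanged the whole 2,3,4-trimethoxyphenyl for bare phenyl, whereas here a single fluorine enters that phenyl. Among the measured compounds shown here, no measured pair shows the effect of one small substituent at this place. The step of a 1.1-fold lower number from compound 2 to compound 3 (0.05 log units; within the scatter) is therefore expected to stay within the scatter of this assay. Compound 3 is estimated at 1000 nM, with a range from 400 nM to 2800 nM.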

Compound 3, half-maximal inhibitory concentration: 1370 nM
Beside the measured number, compound 3's estimate is 1.4-fold (0.14 log units) below it; the measured number falls inside the stated range.
By their numbers in this assay, from the lowest: compounds 2 and 3 (each within the scatter of the next); then compound 1.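

Within the data shown here, putting fluoro in place of hydrogen on this phenyl gives a 1.2-fold higher number from compound 2 to compound 3 (0.09 log units; within the scatter) in this assay, so this is the first reading of a single-atom change at this position, and a fluoro para to a large group leaves the number indistinguishable from that of bare phenyl. The separation from the trimethoxy compound also holds for the fluorinated ring: 4-fluorophenyl in place of 2,3,4-trimethoxyphenyl gives a 2.9-fold lower number from compound 1 to compound 3 (0.46 log units; beyond the scatter), so what the earlier step showed for bare phenyl alone now applies to two different rings, each beyond the scatter from compound 1. Nothing at hand explains either step.

The compounds shown leave open whether the gap to compound 1 follows from all three methoxy groups together or from only one of them, and a single methoxy at this place would begin to separate the two. They also leave open whether an amine, a carboxylic acid or a longer chain on this phenyl would move the number beyond the scatter, as fluoro does not.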